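Exchanging a fused aromatic group on a shared core

The compounds below may be only part of what the source reports. "The series", "measured", "known", "first", "only" and "open" are said of these compounds alone.

For the measured compounds named here, compound 2 `O=c1oc2cc(-c3cnc4[nH]ccc4c3)ccc2n1Cc1ccc(F)cc1` is one of two compounds with numbers so far. In a functional assay on HCT-116 cells (Homo sapiens) for inhibition, read by MTT assay, with a stated time of 72 h (on this read-out lower numbers stand for stronger inhibition and higher numbers for weaker inhibition), compound 2 gives 5990 nM. Compound 1 `N#Cc1cc(-c2ccc3c(c2)oc(=O)n3Cc2ccc(F)cc2)cnc1N` gives 8250 nM in this assay. Compound 2 has the lower of these two numbers, yet the step of a 1.4-fold lower number from compound 1 to compound 2 (0.14 log units; within the scatter) means the two compounds cannot be told apart. Compound 3 `O=c1oc2cc(-c3ccnc4[nH]ncc34)ccc2n1Cc1ccc(F)cc1` differs from compound 2 by a group of 9 heavy atoms (6 carbon, 3 nitrogen; one five-membered aromatic ring with 2 hetero atoms, one six-membered aromatic ring with 1 hetero atom) in place of a group of 9 heavy atoms (7 carbon, 2 nitrogen; one five-membered aromatic ring with 1 hetero atom, one six-membered aromatic ring with 1 hetero atom), on an aromatic carbon. Going by the values given here, the one measured step, from compound 1 to compound 2, also exchanged one fused aromatic group for another on an aromatic carbon of the same core and stayed within the scatter, so a further exchange of this kind is expected to move this assay little. The step expected from compound 2 to compound 3 is therefore a 1.0-fold higher number from compound 2 to compound 3 (0.00 log units; within the scatter). For compound 3 the estimate in this assay is 6000 nM, with a range from 2500 nM to 14000 nM.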

Compound 3, half-maximal inhibitory concentration: > 100000 nM
Compound 3 ended at the assay's limit; the forecaster's own chance of this, stated with the estimate: 5%; middle value at least 16-fold (1.22 log units) from the limit.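

In this assay compound 3 gives > 100000 nM, which is a limit of the assay and not a number: the limit of > 100000 nM in this assay, at which 1 of the 3 values shown sits. Exchanging one fused aromatic group for another on this aromatic carbon can therefore matter greatly, with an at least 16-fold higher number from compound 2 to compound 3 (1.22 log units; beyond the scatter) and an at least 12-fold higher number from compound 1 to compound 3 (1.08 log units; beyond the scatter), whereas the earlier exchange stayed within the scatter. All three groups have the same heavy-atom count, so that count does not separate the large steps from the small one.

The compounds shown do not reveal which feature of the group in compound 3 goes with the large steps, as it differs from the other two groups in more than one way. From the compounds shown here alone, it also remains open whether a simpler group on this carbon, such as a methoxy group or an unsubstituted phenyl ring, would read close to compound 2 or at the limit.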